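Swapping (Piperazin-1-yl)sulfonyl for Methyl: Predicting Compound 3

The compounds below may be only part of what the source reports. "The series", "measured", "known", "first", "only" and "open" are said of these compounds alone.

Compound 1, `CCN1CCN(S(=O)(=O)CCCN2CCC(CNC(=O)c3cccc4c3OCCO4)CC2)CC1`: 0.0501 nM
Compound 2, `O=C(NCC1CCN(CCCS(=O)(=O)N2CCNCC2)CC1)c1cccc2c1OCCO2`: 0.159 nM

In an assay on isolated protein for inhibition of 5-hydroxytryptamine receptor 4 (Homo sapiens) (a lower number here means a stronger inhibitor, a higher number a weaker inhibitor), compound 1 gives 0.0501 nM and compound 2 gives 0.159 nM, the higher of the two numbers. For the measured compounds named here, the single measured step, a 3.2-fold higher number from compound 1 to compound 2 (0.50 log units; beyond the scatter), shows that a small change on the (piperazin-1-yl)sulfonyl group costs modestly. Compound 3, `CCCCN1CCC(CNC(=O)c2cccc3c2OCCO3)CC1`, differs from compound 2 by methyl in place of (piperazin-1-yl)sulfonyl on a saturated chain carbon, three bonds along the chain from an amine nitrogen in a ring. Going by the values given here, no measured step removes this whole group, so the expectation is uncertain, but a larger loss than the measured step seems likely. Compound 3 is expected to give 1.5 nM, within 0.3 nM to 8 nM, an estimated step of a 9.4-fold higher number from compound 2 to compound 3 (0.97 log units; beyond the scatter).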

Compound 3, inhibition constant: 0.794 nM
Compound 3: middle estimate off by 1.9-fold (0.28 log units), on the high side; the measured number falls inside the stated range.
By their numbers in this assay, from the lowest: compound 1; then compound 2; then compound 3.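

Methyl in place of (piperazin-1-yl)sulfonyl gives a 5.0-fold higher number from compound 2 to compound 3 (0.70 log units; beyond the scatter), so this whole group adds to the binding strength but is not needed for it. Measured against the larger (4-ethylpiperazin-1-yl)sulfonyl group, the same kind of replacement gives a 16-fold higher number from compound 1 to compound 3 (1.20 log units; beyond the scatter), a large step. Nothing available explains either step. From the compounds shown here alone, it remains open how a simple methylsulfonyl group, an amide or a carboxylic acid would compare at this position, and whether a longer chain carrying the piperazine would change the picture.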